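A Bromo Swap With Little Expected Change

This account rests on a few compounds, and the source may have more. Where it says the series, first, only, none or still open, it means among the compounds named here.

Among the measured compounds shown here, in a functional assay on Huh-5-2 cells (Homo sapiens) for cytotoxicity, read by microscopy (a lower number here means that less compound is tolerated, a higher number that more compound is tolerated), compound 1 `CC(=O)OC[C@H]1O[C@@H](n2c(SCc3cc4cc(F)ccc4oc3=O)nc3cncnc32)[C@H](OC(C)=O)[C@@H]1OC(C)=O` gives 7600 nM and compound 2 `CC1(C)O[C@@H]2[C@H](O1)[C@H](n1c(SCc3cc4ccccc4oc3=O)nc3cncnc31)O[C@@H]2CO` gives 8800 nM, so compound 2 stands within the scatter of the only other measured value. Compound 3 `CC1(C)O[C@@H]2[C@H](O1)[C@H](n1c(SCc3cc4cc(Br)ccc4oc3=O)nc3cncnc31)O[C@@H]2CO` is compound 2 with bromo in place of hydrogen on an aromatic carbon. For the measured compounds named here, no measured pair shows this change on its own, so the expectation is loose. The expected step of a 1.1-fold lower number from compound 2 to compound 3 (0.04 log units; within the scatter) in this assay stays within the scatter, with no direction favoured. Compound 3 is estimated at 8000 nM, with an expected range from 3500 nM to 18000 nM in this measurement.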

Compound 3, half-maximal cytotoxic concentration: 7500 nM
Compound 3: middle estimate off by 1.1-fold (0.03 log units), on the high side, within the range that was stated.
By their numbers in this assay, from the lowest: compounds 3, 1 and 2 (each within the scatter of the next).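

In this assay, among the compounds shown here, the first direct reading of bromo in place of hydrogen on an aromatic carbon gives a 1.2-fold lower number from compound 2 to compound 3 (0.07 log units; within the scatter) and so leaves compound 2 and compound 3 indistinguishable. A single heavy atom at this place on the shared core therefore has no measurable effect on how much compound the cells tolerate. Nothing further here bears on this result. 

Going by these compounds, whether an amine or a carboxylic acid at the same aromatic carbon would also stay within the scatter remains open. So does whether bromo would behave alike elsewhere on the core.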